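This account rests on a few compounds, and the source may have more. Where it says the series, first, only, none or still open, it means among the compounds named here.

Measured compounds in an assay on HEK293 cells for inhibition of Voltage-dependent T-type calcium channel subunit alpha-1G (Homo sapiens), read by fluorescence, tested at 10 uM; on this read-out lower numbers stand for less inhibition and higher numbers for more inhibition at the one concentration tested (going by the name of the read-out):
compound 1, `CCCc1nc(-c2ccccc2)c(CNCCN2CCN(c3ccc(Cl)cc3)CC2)o1`, gives 55.8%
compound 2, `CCCc1nc(-c2ccccc2)c(CNCCCN2CCN(c3ccccc3Cl)CC2)o1`, gives 64.7%
compound 3, `CCCc1nc(-c2ccccc2)c(CNCCN2CCN(c3ccccc3C(F)(F)F)CC2)o1`, gives 54.6%

Compound 2 has the highest of the three numbers in this assay; compound 1 is nearest, lower by a margin within the scatter, and compound 3 is furthest, lower by a margin beyond it. Compound 4, `CCCc1nc(-c2ccccc2)c(CNCCCN2CCN(c3cccc(C)c3)CC2)o1`, has not yet been measured. It differs from compound 2 as follows: 3-methylphenyl in place of 2-chlorophenyl on an amine nitrogen in a ring. Among the compounds with values here, the one measured step that bears on this, a change of the group on the same ring nitrogen, is a number 1.2 percentage points lower from compound 1 to compound 3 (within the scatter), within the scatter. The step therefore expected is a number 4.7 percentage points lower from compound 2 to compound 4 (within the scatter), nothing beyond the scatter. Compound 4 is estimated at 60%, between 45% and 75%.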

Compound 4, a percentage reported as inhibition, at one concentration (the size of the read-out at that concentration, not a potency): 47.8%
Estimate against measurement, compound 4: 12.2 percentage points above; the range from low to high includes it.
By their numbers in this assay, from the lowest: compounds 4, 3, 1 and 2 (each within the scatter of the next, the first and the last beyond it).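

Placing 3-methylphenyl in place of 2-chlorophenyl on this ring nitrogen gives a number 16.9 percentage points lower from compound 2 to compound 4 (beyond the scatter) in this assay and so shows that the aryl group here can shift the read-out beyond the scatter. The earlier step on the same nitrogen, a number 1.2 percentage points lower from compound 1 to compound 3 (within the scatter) did not show this. Nothing shown gives a cause for the drop.

The compounds leave open whether the step follows the change of chlorine to methyl or the change of ring position; a 3-chlorophenyl or 2-methylphenyl group on the same nitrogen would separate the two.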